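The source may hold more compounds than are shown below. What is called first, only, known or untested is meant among the compounds shown, and "the series" means these compounds.

Compound 1 `Cc1nc(N)sc1CCCNC(=N)NC(=O)CC(C)C1CCCCC1` gives the lower of the two responses measured so far in a functional assay on cardiac atrium for agonist activity at histamine H2 receptor (Cavia porcellus); on this read-out higher numbers stand for larger maximal responses and lower numbers for smaller maximal responses: compound 1 reaches 74%, whereas compound 2 `C[C@@H](CC(=O)NC(=N)NCCCc1c[nH]cn1)c1ccccc1` reaches 102%, a gap beyond the scatter. Compound 3 `Cc1nc(N)sc1CCCNC(=N)NC(=O)C[C@@H](C)C1CCCCC1` is a single enantiomer of compound 1; the change is the two compounds have the same atoms and bonds; at least one stereo element is drawn with a configuration in one of them and without one in the other: 1 of 2 stereo elements differ; a stereocentre at a saturated chain carbon is drawn without a configuration in compound 1 and R in compound 3. Among the measured compounds shown here, no measured pair shows what fixing this configuration does in this assay, so a small step in either direction is expected, possibly none beyond the scatter. The estimated step is a number 4 percentage points higher from compound 1 to compound 3 (within the scatter). For compound 3 the expected value is 78%, within 60% to 96%.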

Compound 3, largest response reached (Emax), in percent of the reference or control that the assay uses: 80%
Compound 3: the middle estimate sits 2 percentage points below what was measured, and the stated range covers the measured number.
By their numbers in this assay, from the lowest: compounds 1 and 3 (each within the scatter of the next); then compound 2.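

In this assay, drawing the stereocentre at the saturated chain carbon as R comes with a number 6 percentage points higher from compound 1 to compound 3 (within the scatter), so this read-out does not separate the R form from the material drawn without a configuration. This is the only measured pair at this position, and a single feature distinguishes its two members: the fact that one of compounds 1 and 3 is drawn with a defined configuration and the other without, at the place where they differ

Open at this stereocentre are the S configuration and what an ethyl group in place of the methyl group would do to the maximal response.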